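Phenyl to Pyridin-3-yl in a Chlorinated Sulfonamide Series

The source may hold more compounds than are shown below. What is called first, only, known or untested is meant among the compounds shown, and "the series" means these compounds.

Compound 1, `C[C@H](Nc1ccc(S(=O)(=O)Nc2nccs2)cc1Cl)c1ccccc1`: 62 mL/min/kg
Compound 2, `C[C@H](Nc1cc(F)c(S(=O)(=O)Nc2nccs2)cc1Cl)c1ccccc1`: 108 mL/min/kg

In an ADME assay on microsomes from liver (Homo sapiens) for metabolic stability, read by LC-MS, using NADPH, with a stated time of 60 min, tested at 1 uM (a lower number here means slower removal, a higher number faster removal of the compound), compound 2 gives 108 mL/min/kg. Of the two numbers measured it holds the higher one, yet compound 1 gives 62 mL/min/kg and the step of a 1.7-fold higher number from compound 1 to compound 2 (0.24 log units; within the scatter) lies within the scatter, so the two compounds are not separated on this read-out.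

Compound 3, `C[C@H](Nc1cc(F)c(S(=O)(=O)Nc2nccs2)cc1Cl)c1cccnc1`, has not been measured. It differs from compound 2 in one place: pyridin-3-yl in place of phenyl on a saturated chain carbon bound to a nitrogen on an aromatic ring and a saturated chain carbon. Among the compounds with values here, the only measured step, a 1.7-fold higher number from compound 1 to compound 2 (0.24 log units; within the scatter), concerns fluoro in place of hydrogen on an aromatic carbon and says nothing about replacing the phenyl by pyridin-3-yl. Within the data shown here, no measured step bears on this change, and the two numbers available give no direction for it.

Compound 3 is therefore expected to stay close to compound 2, with a step of a 1.4-fold lower number from compound 2 to compound 3 (0.13 log units; within the scatter) that need not exceed the scatter. The estimate for compound 3 in this assay is 80 mL/min/kg, with a range from 35 mL/min/kg to 180 mL/min/kg.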

Compound 3, clearance: 22 mL/min/kg
The estimate for compound 3 lay 3.6-fold (0.56 log units) above the measured number, and the stated range ends above it.
By their numbers in this assay, from the lowest: compound 3; then compounds 1 and 2 (each within the scatter of the next).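

Replacing phenyl with pyridin-3-yl on a saturated chain carbon bound to a nitrogen on an aromatic ring and a saturated chain carbon gives the only step in this assay among these compounds that lies beyond the scatter (a 4.9-fold lower number from compound 2 to compound 3 (0.69 log units; beyond the scatter)). The earlier pair differed only by fluoro in place of hydrogen on an aromatic carbon and was not separated, whereas this single change, from 1-phenylethyl to 1-(pyridin-3-yl)ethyl, does separate two compounds on this read-out, with the heavy-atom count unchanged and one ring carbon exchanged for nitrogen. Nothing available explains why the number falls with this change.

The compounds shown leave open whether the same exchange would give a step of similar size on the core of compound 1, which carries hydrogen in place of the fluoro. They also leave open how a pyrimidine ring, a cyclohexyl ring or an added amine would read at this place, and so whether the lower number is particular to pyridin-3-yl.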